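Bromine to chlorine on the triazole-linked phenyl ring

This account rests on a few compounds, and the source may have more. Where it says the series, first, only, none or still open, it means among the compounds named here.

Compound 1 `C=C1C[C@]23C[C@@]1(O)CC[C@H]2c1ccc(OS(=O)(=O)c2ccc(C)cc2)c(C)c1[C@@H]3Cn1cc(-c2ccc(Cl)cc2)nn1` carries a 4-chlorophenyl on its triazole but a different core. In a functional assay on SW480 cells (Homo sapiens) for cytotoxicity, read by MTT assay, with a stated time of 4 days (a lower number here means a stronger inhibitor, a higher number a weaker inhibitor), compound 1 reaches only a limit, > 20000 nM, and no number. Compound 2 `C=C1C(=O)[C@]23C[C@@]1(O)CC[C@H]2c1ccc(OS(=O)(=O)c2ccc(C)cc2)c(C)c1[C@@H]3Cn1cc(-c2ccccn2)nn1` and compound 3 `C=C1C(=O)[C@]23C[C@@]1(O)CC[C@H]2c1ccc(OS(=O)(=O)c2ccc(C)cc2)c(C)c1[C@@H]3Cn1cc(-c2ccc(Br)cc2)nn1` share the core that bears a carbonyl. In this assay compound 2 gives 1970 nM, and compound 3 gives 1590 nM. Among the measured compounds shown here, the single measured step, a 1.2-fold lower number from compound 2 to compound 3 (0.09 log units; within the scatter), exchanges one aryl group for another on the triazole and stays within the scatter. Compound 3 therefore has the lowest of the two numbers shown, with compound 2 nearest and not separated from it beyond the scatter.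

Compound 4 `C=C1C(=O)[C@]23C[C@@]1(O)CC[C@H]2c1ccc(OS(=O)(=O)c2ccc(C)cc2)c(C)c1[C@@H]3Cn1cc(-c2ccc(Cl)cc2)nn1` differs from compound 3 only in the halogen on that ring: chloro in place of bromo on an aromatic carbon. For the measured compounds named here, the one measured step that touches this position, from compound 2 to compound 3, swapped whole aryl groups and moved the number hardly at all, so a smaller swap of one halogen for another is expected to move it even less. For compound 4 in this assay the expected step is a 1.1-fold higher number from compound 3 to compound 4 (0.05 log units; within the scatter), within the scatter. Compound 4 is accordingly estimated at 1800 nM, with a range from 700 nM to 4500 nM.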

Compound 4, half-maximal inhibitory concentration: 2390 nM
Compound 4: middle estimate off by 1.3-fold (0.12 log units), on the low side; the range from low to high includes it.
By their numbers in this assay, from the lowest: compounds 3, 2 and 4 (each within the scatter of the next). At a limit, above all of these: compound 1.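

The halogen itself can now be read directly: in this assay, chloro in place of bromo gives a 1.5-fold higher number from compound 3 to compound 4 (0.18 log units; within the scatter), so on this ring, para to a large group, the two halogens are not told apart. The exchange of pyridin-2-yl for 4-chlorophenyl gives a 1.2-fold higher number from compound 2 to compound 4 (0.08 log units; within the scatter), which means that 4-chlorophenyl, 4-bromophenyl and pyridin-2-yl on the triazole of the shared core all remain unseparated in this assay. Compound 4 also forms a pair with compound 1, which carries the same 4-chlorophenyl but lacks the carbonyl of the shared core, and compound 1 reaches only a limit, > 20000 nM, and no number.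

Whether an amine or a carboxylic acid in the place of the halogen on this ring would move the number beyond the scatter stays open, as the compounds shown vary this position only among halogens and a pyridin-2-yl exchange. Nothing available here gives a reason for the values of these compounds.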